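Aryl exchange from compound 3 to compound 4

This account rests on a few compounds, and the source may have more. Where it says the series, first, only, none or still open, it means among the compounds named here.

Compound 1 `Cc1oc2c([C@H]3CCN(C)C[C@H]3O)c(O)cc(O)c2c(=O)c1C(O)c1ccc(Cl)cc1` reads 15% in a functional assay on MIA PaCa-2 cells (Homo sapiens) for inhibition, read by MTT assay, with a stated time of 48 h, tested at 10 uM (on this read-out higher numbers stand for more inhibition of growth at the one concentration tested and lower numbers for less inhibition of growth), and compound 2 `Cc1oc2c([C@H]3CCN(C)C[C@H]3O)c(O)cc(O)c2c(=O)c1C(O)c1c(Cl)cccc1Cl` reads 0% in this assay under the same conditions. Compound 3 `Cc1oc2c([C@H]3CCN(C)C[C@H]3O)c(O)cc(O)c2c(=O)c1C(O)c1cc(F)cc(F)c1` reads 6% and stands within the scatter of both other compounds, as shown by a number 9 percentage points lower from compound 1 to compound 3 (within the scatter) and by a number 6 percentage points higher from compound 2 to compound 3 (within the scatter) in turn.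

Compound 4 `CCOc1ccc(Br)c(C(O)c2c(C)oc3c([C@H]4CCN(C)C[C@H]4O)c(O)cc(O)c3c2=O)c1` brings the change 2-bromo-5-ethoxyphenyl in place of 3,5-difluorophenyl on a saturated chain carbon bound to an aromatic carbon and an oxygen on a saturated carbon with 2-bromo-5-ethoxyphenyl in place of 3,5-difluorophenyl on a saturated chain carbon bound to an aromatic carbon and an oxygen on a saturated carbon.

All three measured steps are aryl exchanges at this same place. The only one beyond the scatter is a number 15 percentage points lower from compound 1 to compound 2 (beyond the scatter) and it is modest. Going by the values given here, no measured compound carries the 2-bromo-5-ethoxyphenyl group, so these steps offer only loose guidance. No step beyond the scatter is expected, and the estimated change is a number 2 percentage points higher from compound 3 to compound 4 (within the scatter) in this read-out.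

For compound 4 the expected value is 8% with an estimated range (0% to 22%).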

Compound 4, percent growth inhibition at one concentration: 4%
The estimate for compound 4 lay 4 percentage points above the measured number; the measured number falls inside the stated range.
By their numbers in this assay, from the lowest: compounds 2, 4, 3 and 1 (each within the scatter of the next, the first and the last beyond it).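

In this assay the 2-bromo-5-ethoxyphenyl group, the only aryl group shown with an ethoxy chain and a bromine, gives a number 2 percentage points lower from compound 3 to compound 4 (within the scatter) and a number 4 percentage points higher from compound 2 to compound 4 (within the scatter), so this larger group, with its one hydrogen-bond acceptor, stays level with the 3,5-difluorophenyl and 2,6-dichlorophenyl groups at this place. Against the 4-chlorophenyl group the same exchange gives a number 11 percentage points lower from compound 1 to compound 4 (beyond the scatter), a second modest step beyond the scatter, which sets compound 1 apart from both compound 2 and compound 4 but not from compound 3. Nothing at hand accounts for these steps.

Still open, as far as these compounds go, is whether an aminomethyl group or a carboxylic acid on this aryl ring would raise growth inhibition. Also open, from the compounds shown here alone, is what a longer alkyl chain in place of the aryl ring would do.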